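This account rests on a few compounds, and the source may have more. Where it says the series, first, only, none or still open, it means among the compounds named here.

Measured compounds:
compound 1 `CCN(CC)CN1C(=O)/C(=N/NC(N)=S)c2ccccc21` with 73800 nM
compound 2 `CCN(CC)CN1C(=O)/C(=N/NC(=S)Nc2ccc(Cl)cc2)c2cc(Cl)ccc21` with 9100 nM
compound 3 `CCN(CC)CN1C(=O)/C(=N/NC(=S)Nc2ccccc2)c2cc(Cl)ccc21` with 6900 nM

In an ADME assay on CRFK cells (Felis catus) for cytotoxicity (on this read-out higher numbers stand for lower toxicity in this test and lower numbers for higher toxicity in this test), compound 3 gives 6900 nM, the lowest of the three numbers. Its nearest neighbour is compound 2, and the gap between them, a 1.3-fold lower number from compound 2 to compound 3 (0.12 log units; within the scatter), lies within the scatter. The furthest is compound 1, whose number is beyond the scatter from that of compound 3; compound 1 and compound 3 differ in more than one place, so only their two values can be set side by side.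

Compound 4 `CCN(CC)CN1C(=O)/C(=N/NC(=S)Nc2ccccc2)c2ccccc21` has not been measured. It differs from compound 3 in one place: hydrogen in place of chloro on an aromatic carbon. Among the compounds with values here, the one measured step of the same kind, from compound 2 to compound 3, concerned a chloro at another place and gave a 1.3-fold lower number from compound 2 to compound 3 (0.12 log units; within the scatter), within the scatter. Nothing measured shows the effect of removing the chloro at this place. On that basis compound 4 is expected to stay close to compound 3, with a 1.3-fold higher number from compound 3 to compound 4 (0.12 log units; within the scatter) as the estimated step, and no change beyond the scatter is foreseen. Compound 4 is estimated at 9000 nM, with a range from 3500 nM to 25000 nM.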

Compound 4, half-maximal cytotoxic concentration: 32300 nM
The estimate for compound 4 lay 3.6-fold (0.55 log units) below the measured number; the whole stated range lies below it.
By their numbers in this assay, from the lowest: compounds 3 and 2 (each within the scatter of the next); then compound 4; then compound 1.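

In this assay, the chloro at this place on the fused system of two rings carries weight: its exchange for hydrogen gives a 4.7-fold higher number from compound 3 to compound 4 (0.67 log units; beyond the scatter), whereas the same exchange at the other place gives only a 1.3-fold lower number from compound 2 to compound 3 (0.12 log units; within the scatter), so among these compounds the two chloro positions do not behave alike. Within the data shown here, without that chloro, phenyl in place of hydrogen on the amide-type nitrogen gives a 2.3-fold lower number from compound 1 to compound 4 (0.36 log units; beyond the scatter), the first reading of this exchange. Nothing at hand explains either of the two new steps.

As far as these compounds go, whether fluoro, bromo or methoxy at the same place would track chloro or hydrogen remains open. So does whether a chloro on the phenyl ring of compound 4 would shift the number once the fused-system chloro is gone.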